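The source may report more compounds than this note shows. Statements on the series, on what has been measured and on what is new or still open speak of the compounds shown alone.

In a functional assay on LoVo/DX cells (Homo sapiens) for antiproliferative activity, read by sulforhodamine B assay, with a stated time of 72 h (on this read-out higher numbers stand for weaker inhibition and lower numbers for stronger inhibition), compound 1 `CC(=O)N[C@@H](CSC(=S)N[C@H]1CC[C@H](NC(=S)SC[C@H](NC(C)=O)C(=O)O)CC1)C(=O)O` gives 3450 nM, while compound 2 `CCCNC(=S)SC[C@H](NC(C)=O)C(=O)O` gives 112000 nM. Compound 2 therefore stands at the higher of the two numbers, the weaker inhibition, and well beyond the scatter from compound 1. Compound 3 `CCCCNC(=S)SC[C@H](NC(C)=O)C(=O)O` differs from compound 2 by one small change, methyl in place of hydrogen on a saturated chain carbon, three bonds along the chain from an amide-type nitrogen, which turns propyl into butyl. Among the measured compounds shown here, no measured pair shows what a change of this kind does in this assay, so the expectation is only tentative. A modest move toward a lower number is expected, a 1.6-fold lower number from compound 2 to compound 3 (0.20 log units; within the scatter), a step estimated to stay within the scatter. Compound 3 is estimated at 70000 nM, with an expected range from 25000 nM to 150000 nM.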

Compound 3, half-maximal inhibitory concentration: 134000 nM
Compound 3: middle estimate off by 1.9-fold (0.28 log units), on the low side; the range from low to high includes it.
By their numbers in this assay, from the lowest: compound 1; then compounds 2 and 3 (each within the scatter of the next).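

In this assay, among the compounds shown here, methyl in place of hydrogen on a saturated chain carbon, three bonds along the chain from an amide-type nitrogen, gives a 1.2-fold higher number from compound 2 to compound 3 (0.08 log units; within the scatter) and is the first step measured at this position. Propyl and butyl therefore cannot be told apart on this read-out, and this position shows no sensitivity to this one added carbon. Nothing at hand gives a reason for this result.

The compounds shown leave open whether a longer chain, such as hexyl or octyl, would likewise leave the number in place. They also leave open whether an amine or a carboxylic acid in place of this methyl would move it beyond the scatter.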